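Microsomal stability: replacing the ureido tail of compound 2

The source may report more compounds than this note shows. Statements on the series, on what has been measured and on what is new or still open speak of the compounds shown alone.

Among the measured compounds shown here, compound 2 `NC(=O)NCCCCN(C[C@H]1Cc2ncccc2CN1)[C@H]1CCCc2cccnc21` stands lowest of the two numbers so far: in an ADME assay on microsomes from liver (Rattus norvegicus) for metabolic stability, using NADPH, with a stated time of 10 min (on this read-out lower numbers stand for a less stable compound and higher numbers for a more stable compound), compound 2 gives 1%, whereas compound 1 `NCCCCN(C[C@@H]1Cc2cccnc2CN1)[C@H]1CCCc2cccnc21` gives 37%, a gap beyond the usual scatter. Compound 3 `CN(CCCCN(C[C@H]1Cc2ncccc2CN1)[C@H]1CCCc2cccnc21)C1CCOCC1` is the next member to be measured. The change from compound 2 to compound 3 is methyl(oxan-4-yl)amino in place of ureido on a saturated chain carbon, four bonds along the chain from an amine nitrogen. For the measured compounds named here, no step between measured compounds matches this change, so its direction rests on little. An upward step from compound 2 to compound 3 of a number 24 percentage points higher from compound 2 to compound 3 (beyond the scatter) is expected, because compound 2 sits at 1% and leaves little room below. Compound 3 is therefore estimated at 25%, with a range of 3% to 60%.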

Compound 3, percent of the compound remaining: 64%
For compound 3 the middle estimate is 39 percentage points below the measured one; measured number above the stated range.
By their numbers in this assay, from the lowest: compound 2; then compound 1; then compound 3.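

At this place, on a saturated chain carbon, four bonds along the chain from an amine nitrogen, the group strongly affects the result in this assay: methyl(oxan-4-yl)amino in place of ureido gives a large rise (a number 63 percentage points higher from compound 2 to compound 3 (beyond the scatter)). The change removes both hydrogen-bond donors of ureido and adds a six-membered non-aromatic ring, and this single step cannot separate those two differences. Nothing measured here ties the step to a cause.

Going by these compounds, whether the ring is needed stays open. Dimethylamino or acetamido at the same place would help separate the contributions of the ring and the amine.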